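Swapping the aryl group on the urea nitrogen

The source may hold more compounds than are shown below. What is called first, only, known or untested is meant among the compounds shown, and "the series" means these compounds.

Measured in a functional assay on T-24 cells (Homo sapiens) for antiproliferative activity, read by MTT assay, with a stated time of 48 h (a higher number here means a weaker inhibitor, a lower number a stronger inhibitor), so far
compound 1 `O=C(Nc1ccc(Cl)cc1)Nc1cccc(CNc2nccnc2Cl)c1` gives 5470 nM
compound 2 `O=C(Nc1cccc(CNc2nccnc2Cl)c1)NC1CCCC1` gives > 40000 nM
compound 3 `Cc1ccc(NC(=O)Nc2cccc(CNc3nccnc3Cl)c2)cc1Cl` gives 7390 nM

The entry for compound 2 is a limit of the assay and not a number. Compound 3 stands level with compound 1 within the scatter, as a 1.4-fold higher number from compound 1 to compound 3 (0.13 log units; within the scatter) shows. Compound 4 `O=C(Nc1cccc(CNc2nccnc2Cl)c1)Nc1ccc(Cl)cc1Br` carries 2-bromo-4-chlorophenyl in place of 3-chloro-4-methylphenyl on an amide-type nitrogen. Among the compounds with values here, the closest precedent is the exchange of one substituted phenyl for another, a 1.4-fold higher number from compound 1 to compound 3 (0.13 log units; within the scatter), which stayed within the scatter. The large steps involve cyclopentyl, which compound 4 does not carry: an at least 7.3-fold higher number from compound 1 to compound 2 (0.86 log units; beyond the scatter) and an at least 5.4-fold lower number from compound 2 to compound 3 (0.73 log units; beyond the scatter). In this assay no step beyond the scatter is therefore expected, in either direction. The expected change is a 1.2-fold lower number from compound 3 to compound 4 (0.09 log units; within the scatter). The estimate for compound 4 is 6000 nM, with an expected range from 2200 nM to 16000 nM.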

Compound 4, half-maximal inhibitory concentration: 6650 nM
Compound 4: middle estimate off by 1.1-fold (0.04 log units), on the low side, within the range that was stated.
By their numbers in this assay, from the lowest: compounds 1, 4 and 3 (each within the scatter of the next). At a limit, above all of these: compound 2.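

In this assay, bromo in place of hydrogen on an aromatic carbon gives a 1.2-fold higher number from compound 1 to compound 4 (0.08 log units; within the scatter), and the exchange of 3-chloro-4-methylphenyl for 2-bromo-4-chlorophenyl gives a 1.1-fold lower number from compound 3 to compound 4 (0.05 log units; within the scatter), so three differently substituted phenyl groups on this nitrogen now stand within the scatter of each other. The gap to the cyclopentyl compound appears again with this further phenyl group, as an at least 6.0-fold lower number from compound 2 to compound 4 (0.77 log units; beyond the scatter) shows. Compound 2, the only compound here without a phenyl group at this place, holds a limit of the assay and not a number: the limit of > 40000 nM in this assay, at which 1 of the 4 values shown sits.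

The compounds shown leave open whether a methoxy group or a carboxylic acid on the phenyl ring would move the number beyond the scatter. They also leave open how an amine-bearing chain or a longer alkyl chain on this nitrogen would compare.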